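Hydroxymethyl for Ethoxycarbonyl in Cyclopropane Amides

The compounds below may be only part of what the source reports. "The series", "measured", "known", "first", "only" and "open" are said of these compounds alone.

Compound 3 `CCOC(=O)[C@@]1(C(=O)Nc2ccccc2)C[C@H]1c1cc(OC)c(OC)c(OC)c1` was tested in a functional assay on K562 cells (Homo sapiens) for cytotoxicity, read by MTT assay, with a stated time of 48 h; a lower number here means a stronger inhibitor, a higher number a weaker inhibitor. In this assay compound 3 gives only a limit, > 100000 nM. Compound 1 `COc1cc([C@@H]2C[C@@]2(CO)C(=O)Nc2ccccc2)cc(OC)c1OC` carries hydroxymethyl in place of ethoxycarbonyl on a saturated ring carbon. In this assay compound 1 likewise gives only a limit, > 100000 nM. The step that the two limits leave unreadable from compound 3 to compound 1 therefore cannot be read, because both ends share (the limit of > 100000 nM in this assay, at which 3 of the 3 values shown sit). Compound 2 `CCOC(=O)[C@@]1(C(=O)NCc2ccc(C)cc2)C[C@@H]1c1cc(OC)c(OC)c(OC)c1` in this assay also gives only a limit, > 100000 nM. The difference between the core of compound 2 and the core of compound 3 is not broken down here. Compound 4 `COc1cc([C@H]2C[C@@]2(CO)C(=O)NCc2ccc(C)cc2)cc(OC)c1OC` carries the same change, (hydroxymethyl in place of ethoxycarbonyl on a saturated ring carbon). The step that the limit leaves unreadable from compound 2 to compound 4 is expected to be as unreadable as the earlier one, because compound 2 shares (the limit of > 100000 nM in this assay, at which 3 of the 3 values shown sit). Compound 4 is accordingly estimated at 150000 nM, most probably again reported only as a limit.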

Compound 4, half-maximal inhibitory concentration: > 100000 nM
Compound 4: no number, only a limit; the forecaster's own chance of this, stated with the estimate: 85%; the middle value is on the limit's open side.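

No new step can be read from compound 2 to compound 4, since both ends share the same limit: the limit of > 100000 nM in this assay, at which 4 of the 4 values shown sit. The compounds shown leave open what hydroxymethyl in place of ethoxycarbonyl does to potency.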